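From 4-Chlorophenyl to 5-Methylthiophen-2-yl on a Shared Core

The compounds below may be only part of what the source reports. "The series", "measured", "known", "first", "only" and "open" are said of these compounds alone.

Three measured compounds share one core and differ only in the aromatic group attached to a double-bonded chain carbon. In a functional assay on HepG2 cells (Homo sapiens) for cytotoxicity, read by MTT assay, with a stated time of 48 h (a lower number here means a stronger inhibitor, a higher number a weaker inhibitor), compound 1 `COc1ccc(/C=C2/S/C(=N/c3ccccc3)N(Cc3ccncc3)C2=O)cc1` gives 19100 nM. Compound 2 `O=C1/C(=C\c2ccc(Cl)cc2)S/C(=N/c2ccccc2)N1Cc1ccncc1` gives 28800 nM, and compound 3 `O=C1/C(=C\c2cccc(O)c2)S/C(=N/c2ccccc2)N1Cc1ccncc1` gives 17600 nM. Compound 2 stands at the highest of the three numbers, yet the steps of a 1.5-fold higher number from compound 1 to compound 2 (0.18 log units; within the scatter) and a 1.6-fold lower number from compound 2 to compound 3 (0.21 log units; within the scatter) both lie within the scatter, so the three compounds cannot be told apart in this assay.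

Compound 4 `Cc1ccc(/C=C2/S/C(=N/c3ccccc3)N(Cc3ccncc3)C2=O)s1` differs from compound 2 in one place: 5-methylthiophen-2-yl in place of 4-chlorophenyl on a double-bonded chain carbon bound to a double-bonded ring carbon. Within the data shown here, no measured step exchanges a six-membered ring for a five-membered one, so the only steps that bear on this change are those at the same place, a 1.5-fold higher number from compound 1 to compound 2 (0.18 log units; within the scatter) and a 1.6-fold lower number from compound 2 to compound 3 (0.21 log units; within the scatter), and neither left the scatter. The expectation is therefore no step beyond the scatter, with the estimated step of a 1.2-fold lower number from compound 2 to compound 4 (0.08 log units; within the scatter). Compound 4 is expected to give about 24000 nM, within a range from 10000 nM to 60000 nM.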

Compound 4, half-maximal inhibitory concentration: 23100 nM
Compound 4: the middle estimate sits 1.0-fold (0.02 log units) above what was measured; the range from low to high includes it.
By their numbers in this assay, from the lowest: compounds 3, 1, 4 and 2 (each within the scatter of the next).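

In this assay, exchanging a six-membered aromatic ring of carbon only for a five-membered aromatic ring with 1 hetero atom, on a double-bonded chain carbon bound to a double-bonded ring carbon, gives only small steps: a 1.2-fold lower number from compound 2 to compound 4 (0.10 log units; within the scatter), a 1.3-fold higher number from compound 3 to compound 4 (0.12 log units; within the scatter) and a 1.2-fold higher number from compound 1 to compound 4 (0.08 log units; within the scatter). The earlier compounds shown here varied only the substituents on a six-membered ring, whereas compound 4 shows that changing the ring itself also produces no step beyond the scatter, so all four compounds remain indistinguishable in this assay. Nothing available here explains this result.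

All four compounds carry an aromatic ring at this place. From the compounds shown here alone, whether a carboxylic acid, an amine or a longer chain there would produce a step beyond the scatter remains open.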